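The source may hold more compounds than are shown below. What is called first, only, known or untested is meant among the compounds shown, and "the series" means these compounds.

Measured so far:
compound 1, `CCCCCCCCc1ccc(OCC(=O)Cn2nnc(-c3ccccc3)n2)cc1`: 33%
compound 2, `CCCCCCCCc1ccc(OCC(=O)Cn2nnc(-c3ccc(C(=O)O)cc3)n2)cc1`: < 5%
compound 3, `CCCCCCCCc1ccc(OCC(=O)Cn2nnnc2-c2ccccc2Cl)cc1`: 42%

In an ADME assay on S9 fraction from liver (Rattus norvegicus) for metabolic stability, read by LC-MS, using NADPH, with a stated time of 30 min (a lower number here means that less of the compound is left, a higher number that more of the compound is left), compound 3 and compound 1 lie within the usual scatter of each other, so no order between them is claimed. Compound 2 reports only a limit of the assay, (the limit of < 5% in this assay, at which 1 of the 3 values shown sits), and not a number.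

Compound 4, `CCCCCCCCc1ccc(OCC(=O)Cn2nnnc2C(=O)OCC)cc1`, has not yet been measured. It differs from compound 3 by ethoxycarbonyl in place of 2-chlorophenyl on an aromatic carbon. Among the measured compounds shown here, the only measured step that bears on a change at an aromatic carbon is the one from compound 1 to compound 2, a number at least 28 percentage points lower from compound 1 to compound 2 (beyond the scatter), where a carboxy group entered in place of hydrogen and the remaining fraction dropped beyond the scatter. The present change removes a 2-chlorophenyl group and brings in an ethoxycarbonyl group with two hydrogen-bond acceptors, which is a different group in a different setting, so the carboxy step gives only a direction, not a size. For the measured compounds named here, a decrease beyond the scatter is therefore expected, though smaller than the one seen for compound 2. Compound 4 is estimated at 15%, within 3% to 35%, which means an expected step of a number 27 percentage points lower from compound 3 to compound 4 (beyond the scatter).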

Compound 4, percent of the compound remaining: 33%
Estimate against measurement, compound 4: 18 percentage points below, and the stated range covers the measured number.
By their numbers in this assay, from the lowest: compounds 1, 4 and 3 (each within the scatter of the next). At a limit, below all of these: compound 2.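

In this assay, the aromatic carbon between two ring nitrogen atoms accepts ethoxycarbonyl in place of 2-chlorophenyl without a change that can be read (a number 9 percentage points lower from compound 3 to compound 4 (within the scatter)). Among the compounds shown here, for this pair, the remaining fraction therefore holds when the aromatic ring at this position gives way to a group with no ring, and the earlier compounds offered no such exchange at this position. The compounds shown give no measured property that would explain this result, so the pair records an outcome and no cause.

As far as these compounds go, the only large drop comes from a carboxy group entering on another ring (a number at least 28 percentage points lower from compound 1 to compound 2 (beyond the scatter)), and it remains open whether a carboxylic acid in place of the ethoxycarbonyl, or a primary amide or an amine at the same carbon, would give a similar loss in this assay. From the compounds shown here alone, all four compounds also carry the same chain on the shared core, so it remains open how much of the loss in this assay depends on that chain, which a shorter chain or a chain ending in a hydroxyl group could test.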